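Swapping 4-methoxyphenyl for 2,4,6-trihydroxyphenyl in compound 3

The source may report more compounds than this note shows. Statements on the series, on what has been measured and on what is new or still open speak of the compounds shown alone.

Among the compounds with values here, in a functional assay on DU-145 cells (Homo sapiens) for inhibition, read by trypan blue exclusion, with a stated time of 96 h (on this read-out higher numbers stand for weaker inhibition of growth and lower numbers for stronger inhibition of growth), compound 2 `COc1ccc(/C=C(\C(=O)c2ccc(Cl)cc2)S(=O)(=O)c2ccc(Br)cc2)cc1` gives 10000 nM as the only exact number so far. Compound 1 `CN(C)c1ccc(/C=C(\C(=O)c2ccc(Cl)cc2)S(=O)(=O)c2ccc(Br)cc2)cc1` reads > 100000 nM and that is a limit of the assay, not a number. Compound 3 `O=C(/C(=C\c1c(O)cc(O)cc1O)S(=O)(=O)c1ccc(Br)cc1)c1ccc(Cl)cc1` is still unmeasured, and its difference from compound 2 is 2,4,6-trihydroxyphenyl in place of 4-methoxyphenyl on a double-bonded chain carbon bound to a double-bonded chain carbon in one place: 2,4,6-trihydroxyphenyl in place of 4-methoxyphenyl on a double-bonded chain carbon bound to a double-bonded chain carbon. Within the data shown here, the one measured step that bears on this is an at least 10-fold lower number from compound 1 to compound 2 (1.00 log units; beyond the scatter) on the same ring that now leaves, so a change there can clearly move the number in this assay by a wide margin. That step starts from the limit of > 100000 nM in this assay, at which 1 of the 2 values shown sits, and involves different groups, so it hints at size but gives no direction. The expected outcome is a 1.3-fold lower number from compound 2 to compound 3 (0.10 log units; within the scatter) and thus no shift beyond the scatter, though a large move either way remains possible. For compound 3 the estimated value is 8000 nM within an expected range of 1000 nM to 60000 nM in this measurement.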

Compound 3, concentration for 50% growth inhibition: > 100000 nM
Compound 3 ended at the assay's limit (the forecaster's own chance of this, stated with the estimate: 25%); middle value at least 12-fold (1.09 log units) from the limit.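

In this assay, a change away from 4-methoxyphenyl on this double-bonded chain carbon now has a second measured example, and 2,4,6-trihydroxyphenyl gives an at least 10-fold higher number from compound 2 to compound 3 (1.00 log units; beyond the scatter). Both replacements shown for the 4-methoxyphenyl of compound 2, the 4-(dimethylamino)phenyl of compound 1 and the 2,4,6-trihydroxyphenyl of compound 3, therefore weaken growth inhibition beyond the scatter. The step between compound 1 and compound 3 cannot be read, as both end at the same limit, which is not a number: the limit of > 100000 nM in this assay, at which 2 of the 3 values shown sit.

The compounds shown do not separate the effect of adding hydroxy groups from that of losing the methoxy group. From the compounds shown here alone, it also remains open whether a 4-hydroxyphenyl or a plain phenyl group on this carbon would read lower than compound 2.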